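From compound 3 to compound 4: a difluorophenyl swap

The source may hold more compounds than are shown below. What is called first, only, known or untested is meant among the compounds shown, and "the series" means these compounds.

For the measured compounds named here, in an ADME assay on MRC5 cells (Homo sapiens) for inhibition, with a stated time of 72 h (a lower number here means that less compound is needed, a higher number that more compound is needed for the effect), compound 3 (`CO[C@H]1CC[C@H](NC(=O)c2n[nH]cc2NC(=O)c2ccc(F)cc2F)CC1`) gives 11000 nM, the higher of the two numeric values so far. Compound 1 (`CCc1ccccc1C(=O)Nc1c[nH]nc1C(=O)N[C@H]1CC[C@H](OC)CC1`) gives 3400 nM, the nearest value to compound 3. Compound 2 (`COc1cccc(OC)c1C(=O)Nc1c[nH]nc1C(=O)NCC1CCCCC1`) reads > 50000 nM, which is a limit of the assay and not a number.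

The next compound is compound 4 (`CO[C@H]1CC[C@H](NC(=O)c2n[nH]cc2NC(=O)c2cc(F)cc(F)c2)CC1`). The change is 3,5-difluorophenyl in place of 2,4-difluorophenyl on a carbonyl carbon, with the same atoms joined differently.

Going by the values given here, only one measured step touches this place: a 3.2-fold higher number from compound 1 to compound 3 (0.51 log units; beyond the scatter), with 2,4-difluorophenyl in place of 2-ethylphenyl. That step is modest but beyond the scatter, and it shows that a change on this carbonyl carbon can move the number in this assay. Among the compounds with values here, it exchanges a different pair of groups, however, and no measured compound carries 3,5-difluorophenyl, so it gives no direction for the present swap. No shift in either direction is therefore favoured, and the step is expected to stay within the scatter or reach about the size of the modest step at most.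

The expected step is no change at the digits printed from compound 3 to compound 4 (within the scatter). For compound 4 the estimated value is 11000 nM, with an expected range of 4000 nM to 30000 nM.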

Compound 4, half-maximal effective concentration: 600 nM
Estimate against measurement, compound 4: 18-fold (1.26 log units) above; the whole stated range lies above it.
By their numbers in this assay, from the lowest: compound 4; then compound 1; then compound 3. At a limit, above all of these: compound 2.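

In this assay, moving the two fluorines around the phenyl on this carbonyl carbon is enough on its own to shift the number by a large margin (an 18-fold lower number from compound 3 to compound 4 (1.26 log units; beyond the scatter)), although the atoms, the heavy-atom count and the rest of the molecule stay the same. The earlier step at this place exchanged two different groups and was only modest, so it did not show that the arrangement of the same atoms could matter this much here. The 3,5-difluorophenyl group also compares well with 2-ethylphenyl (a 5.7-fold lower number from compound 1 to compound 4 (0.75 log units; beyond the scatter)), which makes compound 4 the lowest of the three compounds with numeric values, all of which share the same remainder and differ only on this carbonyl carbon.

The compounds shown give no measurement that accounts for the gap between the two difluorophenyl groups. Also open, on these data alone, is how a monofluorophenyl, a dichlorophenyl or a pyridine ring on this carbonyl carbon would read, and whether the low number of compound 4 would hold with a different group on the other amide.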